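A few compounds are considered here, and "the series" means these few. Any claim that something is new, unique, unknown or untested is made for them only; others in the source may bear on it.

Three related compounds have been tested in an ADME assay on MT4 cells (Homo sapiens) for cytotoxicity, read by MTT assay, with a stated time of 96 h; on this read-out higher numbers stand for lower toxicity in this test and lower numbers for higher toxicity in this test. Compound 2 (`Cc1cccc(C2CC(c3ccc(Oc4ccccc4)cc3)=NN2c2ccc(S(N)(=O)=O)cc2)c1`) gives 35000 nM, and compound 3 (`Cc1ccc(C2CC(c3ccc(OCc4ccccc4)cc3)=NN2c2ccc(S(N)(=O)=O)cc2)cc1`) gives 35000 nM, so the two stand level at the digits shown. Compound 1 (`NS(=O)(=O)c1ccc(N2N=C(c3ccc(OCc4ccccc4)cc3)CC2c2ccc(F)cc2)cc1`) gives > 100000 nM, which is a limit of the assay and not a number.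

Compound 4 (`Cc1cccc(C2CC(c3ccc(OCc4ccccc4)cc3)=NN2c2ccc(S(N)(=O)=O)cc2)c1`) keeps the atoms of compound 3 but joins them differently: it has 3-methylphenyl in place of 4-methylphenyl on a saturated ring carbon of the core (3-methylphenyl in place of 4-methylphenyl on a saturated ring carbon).

Among the measured compounds shown here, only one measured step bears on this change. It is an at least 2.8-fold lower number from compound 1 to compound 3 (0.45 log units; beyond the scatter), in which methyl replaced fluoro on an aromatic carbon. Its size is only a lower bound, since one end is the limit of compound 1, and it swaps one group for another. For the measured compounds named here, in compound 4, the methyl group is kept and only its place on the phenyl ring changes, so this is a smaller edit, and no measured step shows such a move on its own. No clear shift in this assay is therefore expected, and any direction would be a guess. The expected change is no change at the digits printed from compound 3 to compound 4 (within the scatter), which would lie within the scatter. Compound 4 is estimated at 35000 nM, with an expected range of 15000 nM to 80000 nM.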

Compound 4, half-maximal cytotoxic concentration: 44000 nM
The estimate for compound 4 lay 1.3-fold (0.10 log units) below the measured number, and the stated range covers the measured number.
By their numbers in this assay, from the lowest: compounds 2, 3 and 4 (each within the scatter of the next). At a limit, above all of these: compound 1.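

In this assay, 3-methylphenyl in place of 4-methylphenyl on a saturated ring carbon gives a 1.3-fold higher number from compound 3 to compound 4 (0.10 log units; within the scatter), so this read-out does not separate the two placements of the methyl group; benzyl in place of phenyl on an oxygen on an aromatic ring likewise gives a 1.3-fold higher number from compound 2 to compound 4 (0.10 log units; within the scatter). The fluorinated compound still stands apart from the new compound, as 3-methylphenyl in place of 4-fluorophenyl on the same saturated ring carbon gives an at least 2.2-fold lower number from compound 1 to compound 4 (0.35 log units; beyond the scatter), and this size is only a lower bound. Compound 1 sits at a limit of the assay and not at a number: the limit of > 100000 nM in this assay, at which 1 of the 4 values shown sits.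

The compounds shown do not tell how far compound 1 truly stands from the methyl compounds, or whether the fluoro group and the methyl group would differ in the same way at the other place on the phenyl ring. They also leave open whether a more different group on that ring, such as an amine or a carboxylic acid, or a longer chain on the oxygen, would move the number beyond the scatter.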